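Shortening the ether chain and dropping its hydroxyl

The source may report more compounds than this note shows. Statements on the series, on what has been measured and on what is new or still open speak of the compounds shown alone.

Compound 1: `Cc1cc(OCCCO)cc(C)c1-c1cccc(COc2ccc(OCC(=O)O)c(F)c2)c1`, 2.73
Compound 2: `Cc1cc(OCCCS(C)(=O)=O)cc(C)c1-c1cccc(COc2ccc(N(CC(=O)O)C(=O)c3ccoc3)cc2)c1`, "not determined" (no result reported)
Compound 3: `CC(=O)N(CC(=O)O)c1ccc(OCc2cccc(-c3c(C)cc(OCCCS(C)(=O)=O)cc3C)c2)cc1C`, "not determined" (no result reported)
Compound 4: `CCOc1cc(C)c(-c2cccc(COc3ccc(OCC(=O)O)c(F)c3)c2)c(C)c1`, not yet measured

In a physicochemical assay for lipophilicity, using the shake flask method, in phosphate buffer, measured as octanol-water partition, with a stated time of 24 h, at pH 7.4, tested at 100 uM (a higher number here means a more lipophilic compound, a lower number a more polar compound), compound 1 gives 2.73. Among the measured compounds shown here, compound 2 and compound 3 carry no number in this assay, so compound 1 holds the only value shown, and there is no measured pair from which the size of any step could be read.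

Compound 4 differs from compound 1 in one place: hydrogen in place of hydroxymethyl on a saturated chain carbon, two bonds along the chain from an oxygen on an aromatic ring. The difference, cut one bond further out, reads as 3-hydroxypropoxy to ethoxy.

For the measured compounds named here, with no measured step to lean on, the expectation rests on the change alone: the hydroxyl leaves and one chain carbon leaves with it. The first is expected to raise the distribution coefficient, the second to lower it a little, and the net step from compound 1 to compound 4 is expected to be a number 0.67 log units higher from compound 1 to compound 4 (beyond the scatter), beyond the scatter and toward the lipophilic side.

Compound 4 is therefore estimated at 3.4 in this assay, within 2.9 to 3.9.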

Compound 4, distribution coefficient: 3.48
For compound 4 the middle estimate is 0.08 log units below the measured one; the range from low to high includes it.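

In this assay, among the compounds shown here, the exchange of 3-hydroxypropoxy for ethoxy gives a number 0.75 log units higher from compound 1 to compound 4 (beyond the scatter), the first step of any size that can be read. For the compounds shown here, it shows that the read-out responds to a change at this saturated chain carbon, two bonds along the chain from an oxygen on an aromatic ring, which the single number for compound 1 could not show. The step counts the departure of hydroxymethyl as one unit, and no independent evidence bears on why it has this size.

The compounds shown leave open how the step divides between the hydroxyl and the chain length, a division that a plain propoxy chain or a 2-hydroxyethoxy chain would help to settle. Going by these compounds, how an amine at the end of the chain would read also remains open.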